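Primary amide to pyrimidinyl amide on a chlorophenyl core

The source may hold more compounds than are shown below. What is called first, only, known or untested is meant among the compounds shown, and "the series" means these compounds.

Compound 1 `CC(C)C(C(N)=O)c1ccc(Cl)cc1` reaches only a limit in a functional assay on CHO cells for agonist activity at Free fatty acid receptor 2 (Homo sapiens), read by cAMP accumulation; on this read-out lower numbers stand for smaller maximal responses and higher numbers for larger maximal responses: its value of < 30% is a limit of the assay, not a number. Compound 2 `CC(C)[C@H](C(=O)Nc1ccccc1)c1ccc(Cl)cc1` likewise reaches a limit; in this assay compound 2 gives < 30%. Both measured values sit at the limit of < 30% in this assay, at which 2 of the 2 values shown sit. Compound 3 `CC(C)C(C(=O)Nc1ncccn1)c1ccc(Cl)cc1` is not yet measured and differs from compound 1 by pyrimidin-2-yl in place of hydrogen on an amide-type nitrogen. Because the limit of < 30% in this assay, at which 2 of the 2 values shown sit, holds both measured values, no step beyond the scatter is expected in this assay, and the estimated step that the limit leaves unreadable from compound 1 to compound 3 is small. Compound 3 is expected to give 20%, within 5% to 45%.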

Compound 3, largest response reached (reported as efficacy), in percent of the reference or control that the assay uses: 50%
Compound 3: the middle estimate sits 30 percentage points below what was measured, and the stated range ends below it.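

In this assay, pyrimidin-2-yl in place of hydrogen on the amide-type nitrogen gives a number at least 20 percentage points higher from compound 1 to compound 3 (beyond the scatter). Compound 1 gives < 30%, which is a limit of the assay and not a number. This position is therefore the first shown to take a substituent that gives a readable maximal response, and compound 3 stands clear of the floor: the limit of < 30% in this assay, at which 2 of the 3 values shown sit.

Open, on these data alone, is how a pyridin-2-yl or thiazol-2-yl group on the same nitrogen would read in this assay. Also open, as far as these compounds go, is whether a carboxylic acid on the pyrimidin-2-yl ring would change the response.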